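A Carbamoyl on the Piperidine Ring

This account rests on a few compounds, and the source may have more. Where it says the series, first, only, none or still open, it means among the compounds named here.

Measured in a physicochemical assay for solubility, in phosphate buffer, at pH 7.4; on this read-out higher numbers stand for higher solubility and lower numbers for lower solubility:
- compound 1 `OC1CN(c2nccnc2OC2CN(c3ccc4ccccc4n3)C2)C1`: 41000 nM
- compound 2 `c1ccc2nc(N3CC(Oc4nccnc4N4CCCCC4)C3)ccc2c1`: < 1000 nM

Compound 2 gives < 1000 nM, which is a limit of this assay and not a number. Compound 3 `NC(=O)C1CCN(c2nccnc2OC2CN(c3ccc4ccccc4n3)C2)CC1` has not yet been measured. It departs from compound 2 by one change, carbamoyl in place of hydrogen on a saturated ring carbon. Within the data shown here, only one measured step bears on this change, namely an at least 41-fold lower number from compound 1 to compound 2 (1.61 log units; beyond the scatter). That step is large and beyond the scatter, and it concerns the same substituent on the shared core. It is a single step and a different change, so it offers only a loose guide. An estimated at least 12-fold higher number from compound 2 to compound 3 (1.07 log units; beyond the scatter) is expected in this assay, towards higher numbers. For compound 3 the expected value is 12000 nM, with an estimated range of 2000 nM to 60000 nM.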

Compound 3, solubility: 14000 nM
Compound 3: middle estimate off by 1.2-fold (0.07 log units), on the low side, and the stated range covers the measured number.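

In this assay the value of compound 2 is a limit and not a number: the limit of < 1000 nM in this assay, at which 1 of the 3 values shown sits.

Carbamoyl on the saturated ring carbon, three ring bonds from the ring nitrogen, gives a large rise in the number (an at least 14-fold higher number from compound 2 to compound 3 (1.14 log units; beyond the scatter)), so the fall seen on going to piperidin-1-yl is not fixed for every six-membered ring at this place on the shared core. Set against 3-hydroxyazetidin-1-yl, 4-carbamoylpiperidin-1-yl still gives a modest fall (a 2.9-fold lower number from compound 1 to compound 3 (0.47 log units; beyond the scatter)), so much of the earlier fall is regained, though not all of it.

The compounds shown leave open whether a carboxylic acid, an amine or a hydroxyl on the same ring carbon would give a step of similar size. Going by these compounds, the full size of the carbamoyl step also stays open, with only a limit for compound 2.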